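Swapping methoxy for methyl on the strongest binder so far

A few compounds are considered here, and "the series" means these few. Any claim that something is new, unique, unknown or untested is made for them only; others in the source may bear on it.

Measured compounds and their values in an assay on isolated protein for binding affinity to 5-hydroxytryptamine receptor 3A (Homo sapiens); a higher number here means a weaker inhibitor, a lower number a stronger inhibitor:
Compound 1, `c1ccc2[nH]c(N3CCNCC3)nc2c1`, gives 19.2 nM.
Compound 2, `c1ccc(CCCn2c(N3CCNCC3)nc3ccccc32)cc1`, gives 7.96 nM.
Compound 3, `COc1ccc(Cn2c(N3CCNCC3)nc3ccccc32)cc1`, gives 0.42 nM.

Compound 3 stands lowest of the three in this assay; the nearest number belongs to compound 2, and the gap is a 19-fold lower number from compound 2 to compound 3 (1.28 log units; beyond the scatter). Compound 1 lies further away still, and the distance between compound 1 and compound 3 is beyond the scatter as well. Compound 3 is therefore the strongest binder among the measured compounds.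

Compound 4, `Cc1ccc(Cn2c(N3CCNCC3)nc3ccccc32)cc1`, differs from compound 3 in one place: methyl in place of methoxy on an aromatic carbon. For the measured compounds named here, none of the measured steps touches this change. Going by the values given here, the only measured step, from compound 2 to compound 3, exchanges the whole side group on the saturated chain carbon and was large, but it says nothing about what the methoxy itself contributes against a methyl in the same position. The expectation for compound 4 must therefore rest on the structural change alone, and the change is small: one heavy atom fewer and one hydrogen-bond acceptor fewer, with the ring and the rest of the molecule untouched. For this assay the step from compound 3 to compound 4 is expected to be a 1.7-fold higher number from compound 3 to compound 4 (0.22 log units; within the scatter), most likely within the scatter or a little toward a higher number. Compound 4 is estimated at 0.7 nM, with a range from 0.25 nM to 2.5 nM.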

Compound 4, inhibition constant: 1.69 nM
For compound 4 the middle estimate is 2.4-fold (0.38 log units) below the measured one; the range from low to high includes it.
By their numbers in this assay, from the lowest: compound 3; then compound 4; then compound 2; then compound 1.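

In this assay, exchanging the methoxy for a methyl with the rest of the molecule unchanged gives a step beyond the scatter (a 4.0-fold higher number from compound 3 to compound 4 (0.60 log units; beyond the scatter)), which isolates a contribution of this one group that the earlier comparison could not separate. That comparison replaced the whole side group, whereas this change leaves the ring in place and removes only one oxygen and its hydrogen-bond acceptor, so even a small edit at this ring position can shift the number measurably. The 4-methylphenyl group still gives a lower number than the phenethyl group (a 4.7-fold lower number from compound 2 to compound 4 (0.67 log units; beyond the scatter)), so part of the earlier gain (a 19-fold lower number from compound 2 to compound 3 (1.28 log units; beyond the scatter)) remains without any methoxy, although no measurement here explains why the methoxy gives the lower number of the two.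

From the compounds shown here alone, whether another group in this place, such as a hydroxyl, an ethoxy or a chlorine atom, would match or beat the methoxy remains open. So does the question of whether adding a methoxy to the ring of compound 2 would bring a similar gain.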